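A few compounds are considered here, and "the series" means these few. Any claim that something is new, unique, unknown or untested is made for them only; others in the source may bear on it.

Measured so far, in a functional assay on the whole organism with Mus musculus as the target, in the maximal electroshock model; on this read-out higher numbers stand for an effect only at larger amounts of compound and lower numbers for an effect already at smaller amounts:

Compound 1, `c1ccc(-n2nncc2-c2ccncc2)cc1`, gives 78.8 mg/kg.
Compound 2, `FC(F)(F)c1cccc(-n2nncc2-c2ccncc2)c1`, gives 68.2 mg/kg.
Compound 3, `c1ccc(-n2nncc2-c2cccnc2)cc1`, gives 76.4 mg/kg.

Compound 4, `FC(F)(F)c1ccc(-n2nncc2-c2cccnc2)cc1`, has not yet been measured in this assay. Compound 2 differs from compound 1 by trifluoromethyl in place of hydrogen on an aromatic carbon, and this change gave a 1.2-fold lower number from compound 1 to compound 2 (0.06 log units; within the scatter). The difference between the core of compound 1 and the core of compound 3 is not broken down here; the two values show nothing beyond the scatter. Compound 4 differs from compound 3 by trifluoromethyl in place of hydrogen on an aromatic carbon, the same kind of change as from compound 1 to compound 2, but the group enters para to a large group rather than meta to a large group. Because the earlier step was a 1.2-fold lower number from compound 1 to compound 2 (0.06 log units; within the scatter), a similarly small step is expected, a 1.2-fold lower number from compound 3 to compound 4 (0.06 log units; within the scatter). Compound 4 is therefore estimated at 66 mg/kg, between 35 mg/kg and 130 mg/kg.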

Compound 4, dose for half-maximal effect: 92.3 mg/kg
Compound 4: middle estimate off by 1.4-fold (0.15 log units), on the low side; measured number inside the range.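

In this assay, trifluoromethyl in place of hydrogen gives a 1.2-fold higher number from compound 3 to compound 4 (0.08 log units; within the scatter) and this step can be set beside the earlier one on the other core: the same change on two cores in this assay, a 1.2-fold lower number (0.06 log units; within the scatter) from compound 1 to compound 2 and a 1.2-fold higher number (0.08 log units; within the scatter) from compound 3 to compound 4, 1.4-fold (0.14 log units) apart, within the scatter of two such steps. On these two cores, then, the change moves the number no further than repeat measurements would, and the two steps cannot be told apart. This does not show that the change carries over unaltered, since steps this small could hide a real influence of the core or of the group's position, which is para to a large group in compound 4 but elsewhere on the ring in compound 2.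

As far as these compounds go, whether another group on that ring, such as an amine, a carboxylic acid or a longer chain, would shift the number beyond the scatter stays open.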